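Swapping a Benzofuran for a Thiophene on a Nucleoside Core

The source may report more compounds than this note shows. Statements on the series, on what has been measured and on what is new or still open speak of the compounds shown alone.

Measured compounds:
Compound 1, `Nc1nc(N)c2c(-c3ccoc3)cn([C@@H]3O[C@H](CO)[C@@H](O)[C@H]3O)c2n1`: > 20000 nM in a functional assay on CCRF-CEM cells (Homo sapiens), read by MTT assay, with a stated time of 72 h; a higher number here means a weaker inhibitor, a lower number a stronger inhibitor
Compound 2, `O=c1[nH]cnc2c1c(-c1cc3ccccc3o1)cn2[C@@H]1O[C@H](CO)[C@@H](O)[C@H]1O`: > 20000 nM in this assay

For compound 1 the result > 20000 nM is a limit of the assay, not a number. For compound 2 the result > 20000 nM is likewise only a limit. Compound 2 therefore stands at the limit of > 20000 nM in this assay, at which 2 of the 2 values shown sit, and no ordering between the two measured compounds can be read from these results.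

Compound 3, `O=c1[nH]cnc2c1c(-c1ccsc1)cn2[C@@H]1O[C@H](CO)[C@@H](O)[C@H]1O`, differs from compound 2 in one place: thiophen-3-yl in place of 1-benzofuran-2-yl on an aromatic carbon. Among the compounds with values here, because both known values are limits, no measured step exists to guide the direction, and no step beyond the scatter is expected in this assay. Compound 3 is expected to give about 25000 nM, with a range from 8000 nM to 80000 nM. The step this estimate means, a step that the limit leaves unreadable from compound 2 to compound 3, is expected to stay within the scatter, most likely again as a limit.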

Compound 3, half-maximal inhibitory concentration: 14500 nM
The estimate for compound 3 lay 1.7-fold (0.24 log units) above the measured number; measured number inside the range.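

With compound 3, this position on the shared core gives a readable number for the first time among these compounds: compound 3 gives 14500 nM in this assay. Thiophen-3-yl in place of 1-benzofuran-2-yl, a change that drops the six-membered aromatic ring of carbon only, gives an at least 1.3-fold lower number from compound 2 to compound 3 (0.13 log units; that floor lies within the scatter). As far as these compounds go, only that floor can be read, so the change shows no step beyond the scatter, and its full size stays unknown.

Open, from the compounds shown here alone, is how a phenyl ring, a methyl group or an amine on this aromatic carbon would read in this assay. Also open, going by these compounds, is whether any such group would move the number at this position beyond the scatter of compound 3.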